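A few compounds are considered here, and "the series" means these few. Any claim that something is new, unique, unknown or untested is made for them only; others in the source may bear on it.

Working notes on the series, read in a functional assay on DU-145 cells (Homo sapiens) for inhibition, read by trypan blue exclusion, with a stated time of 96 h; on this read-out higher numbers stand for weaker inhibition of growth and lower numbers for stronger inhibition of growth. Compound 1 `Cc1ccc(S/C(=C/c2ccc(N(C)C)cc2)C(=O)c2ccc(Cl)cc2)cc1` gives > 100000 nM, and this value is a limit of the assay, not a number. Compound 2 `Cc1ccc(S/C(=C/c2ccc[nH]2)C(=O)c2ccc(Cl)cc2)cc1` gives 10000 nM. For the measured compounds named here, compound 3 `Cc1ccc(S/C(=C/c2cc(C)cc(C)c2)C(=O)c2ccc(Cl)cc2)cc1` gives 50000 nM, the higher of the two numbers measured so far. The gap to its nearest neighbour is a 5.0-fold higher number from compound 2 to compound 3 (0.70 log units; beyond the scatter).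

The next structure is compound 4 `COc1ccc(/C=C(/Sc2ccc(C)cc2)C(=O)c2ccc(Cl)cc2)cc1`, and the change is 4-methoxyphenyl in place of 3,5-dimethylphenyl on a double-bonded chain carbon bound to a double-bonded chain carbon.

All three measured steps fall at this same place. The closest comparison is an at least 2.0-fold lower number from compound 1 to compound 3 (0.30 log units; that floor lies within the scatter). It links two compounds that both carry a substituted phenyl, and its floor lies within the scatter. The larger steps, an at least 10-fold lower number from compound 1 to compound 2 (1.00 log units; beyond the scatter) and a 5.0-fold higher number from compound 2 to compound 3 (0.70 log units; beyond the scatter), both involve the 1H-pyrrol-2-yl of compound 2, which compound 4 does not carry. They therefore say little about an exchange of one substituted phenyl for another. No step beyond the scatter is expected in this assay, in either direction.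

The estimated step is a 1.2-fold higher number from compound 3 to compound 4 (0.08 log units; within the scatter). For compound 4 the expected value is 60000 nM, with an estimated range of 15000 nM to 200000 nM.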

Compound 4, concentration for 50% growth inhibition: 1000 nM
Beside the measured number, compound 4's estimate is 60-fold (1.78 log units) above it, outside the stated range (below it).
By their numbers in this assay, from the lowest: compound 4; then compound 2; then compound 3. At a limit, above all of these: compound 1.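

Working from this assay, exchange of one substituted phenyl for another on a double-bonded chain carbon bound to a double-bonded chain carbon proves far from neutral: a 50-fold lower number from compound 3 to compound 4 (1.70 log units; beyond the scatter) separates two groups that each hold 8 heavy atoms and one six-membered aromatic ring of carbon only, the entering group differing in its oxygen and its hydrogen-bond acceptor. The same group also outdoes the five-membered ring of the series, with a 10-fold lower number from compound 2 to compound 4 (1.00 log units; beyond the scatter) on record, and methoxy in place of dimethylamino on an aromatic carbon gives an at least 100-fold lower number from compound 1 to compound 4 (2.00 log units; beyond the scatter) as a floor, so a substituted phenyl at this place can give either the lowest number shown or the limit of the series. Compound 1 gives > 100000 nM and that value is a limit of the assay, not a number: the limit of > 100000 nM in this assay, at which 1 of the 4 values shown sits.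

The compounds shown leave open whether the oxygen or the placing of the group carries the gain, which a 4-hydroxyphenyl, a 4-ethoxyphenyl or a 3-methoxyphenyl at this place would test. They also leave open whether the gain holds with the 4-chlorophenyl or the 4-methylphenyl of the shared core replaced, for example by an unsubstituted phenyl.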